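Methoxy for Methyl in a Level Series

This account rests on a few compounds, and the source may have more. Where it says the series, first, only, none or still open, it means among the compounds named here.

Measured in a functional assay on HepG2 cells (Homo sapiens) for antiproliferative activity, read by CCK-8 assay, with a stated time of 72 h; a higher number here means a weaker inhibitor, a lower number a stronger inhibitor:
- compound 1 `Nc1ccccc1NC(=O)c1ccc(COc2ccccc2)cc1`: 6700 nM
- compound 2 `CCc1ccc(OCc2ccc(C(=O)Nc3ccccc3N)cc2)cc1`: 6960 nM
- compound 3 `Cc1ccc(OCc2ccc(C(=O)Nc3ccccc3N)cc2)cc1`: 6590 nM

Compound 3 stands level with the other two compounds, as the measured gaps show: a 1.0-fold lower number from compound 1 to compound 3 (0.01 log units; within the scatter) and a 1.1-fold lower number from compound 2 to compound 3 (0.02 log units; within the scatter).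

The next compound is compound 4 `COc1ccc(OCc2ccc(C(=O)Nc3ccccc3N)cc2)cc1`. It has methoxy in place of methyl on an aromatic carbon, para to a large group: methoxy in place of methyl on an aromatic carbon. Within the data shown here, no measured pair makes this exact swap, so the evidence is indirect. Two steps put a small group on an aromatic carbon: a 1.0-fold lower number from compound 1 to compound 3 (0.01 log units; within the scatter) and a 1.0-fold higher number from compound 1 to compound 2 (0.02 log units; within the scatter). Both are small and lie within the scatter. Three closely related compounds are a thin basis, and none of them carries methoxy, so the range is kept wide. Even so, no change beyond the scatter is expected in this assay. The expected step is a 1.0-fold lower number from compound 3 to compound 4 (0.01 log units; within the scatter). For compound 4 the estimated value is 6500 nM, with an expected range of 3500 nM to 12000 nM.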

Compound 4, half-maximal inhibitory concentration: 4200 nM
Compound 4: middle estimate off by 1.5-fold (0.19 log units), on the high side; measured number inside the range.
By their numbers in this assay, from the lowest: compounds 4, 3, 1 and 2 (each within the scatter of the next).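

In this assay, replacing methyl with methoxy gives a 1.6-fold lower number from compound 3 to compound 4 (0.20 log units; within the scatter) and puts a hydrogen-bond acceptor on this aromatic carbon, para to a large group, which hydrogen, methyl and ethyl do not provide. Set against ethyl and hydrogen, methoxy gives a 1.7-fold lower number from compound 2 to compound 4 (0.22 log units; within the scatter) and a 1.6-fold lower number from compound 1 to compound 4 (0.20 log units; within the scatter) as well, so hydrogen, methyl, ethyl and methoxy at this position cannot be told apart here, even with an added oxygen atom in the group. No supporting data bear on this result.

The compounds shown leave open whether any group at this position can move the number beyond the scatter. An amine, a carboxylic acid or a longer chain such as butoxy would test this with groups unlike those seen so far.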